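The source may hold more compounds than are shown below. What is called first, only, known or untested is meant among the compounds shown, and "the series" means these compounds.

Of the compounds shown here, three built on one shared core have been measured in an assay on membranes from HEK293 cells for displacement of a labelled ligand from adenosine receptor A2b (Homo sapiens), read by scintillation counting, with a stated time of 30 min, tested at 1 uM (a higher number here means more inhibition at the concentration tested (going by the name of the read-out), a lower number less inhibition), and they differ only in the group carried on the carbonyl carbon. Compound 1 `CC1=C(C(=O)C2CC2)C(c2cccs2)NC(=O)N1` carries a cyclopropyl there and gives 1% in this assay. Compound 2 `CCCC(=O)C1=C(C)NC(=O)NC1c1cccs1` carries a propyl and gives 9% in this assay. Compound 3 `CC1=C(C(=O)SC(C)C)C(c2cccs2)NC(=O)N1` carries an isopropylsulfanyl and gives 1% in this assay. Compound 3 stands level with compound 1 at the digits shown, and its gap to compound 2 lies within the scatter of this assay; the step of a number 8 percentage points lower from compound 2 to compound 3 (within the scatter) and the step of no change at the digits printed from compound 1 to compound 3 (within the scatter) are both within the scatter, as is the step of a number 8 percentage points higher from compound 1 to compound 2 (within the scatter).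

Compound 4 `CC1=C(C(=O)OC2CCCC2)C(c2cccs2)NC(=O)N1` is the next member of this series and has not yet been measured. It differs from compound 3 in one place: cyclopentyloxy in place of isopropylsulfanyl on a carbonyl carbon. All three measured steps change the same position, the group on the carbonyl carbon, and none of them moved this assay beyond the scatter. On that basis compound 4 is expected to behave like the three measured compounds, with a step of a number 3 percentage points higher from compound 3 to compound 4 (within the scatter) that stays within the scatter. The estimate for compound 4 in this assay is therefore 4%, with a range from -6% to 16%.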

Compound 4, a percentage reported as inhibition, at one concentration (the size of the read-out at that concentration, not a potency): 1%
The estimate for compound 4 lay 3 percentage points above the measured number; the range from low to high includes it.
By their numbers in this assay, from the lowest: compounds 1, 3, 4 and 2 (each within the scatter of the next).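

In this assay, the swap of isopropylsulfanyl for cyclopentyloxy gives no change at the digits printed from compound 3 to compound 4 (within the scatter), so a group joined through oxygen and carrying a five-membered carbon ring reads no differently at this place from one joined through sulfur. Among the compounds shown here, the comparisons with the two groups joined through carbon agree, with a number 8 percentage points lower from compound 2 to compound 4 (within the scatter) and no change at the digits printed from compound 1 to compound 4 (within the scatter), and this extends the flat picture at the carbonyl carbon to a fourth group and a third kind of linking atom: no step among cyclopropyl, propyl, isopropylsulfanyl and cyclopentyloxy leaves the scatter. No measurement offered here accounts for this lack of separation.

The four compounds leave open whether any group on this carbonyl carbon can lift the read-out clear of the others, for instance an amine or a longer chain such as hexyl. They also leave open whether the insensitivity seen here holds once another part of the shared core is changed, since a single tested concentration with numbers this close says little about how these compounds would compare at higher concentrations.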